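Chloro for trifluoromethyl on the benzyl group of compound 3

A few compounds are considered here, and "the series" means these few. Any claim that something is new, unique, unknown or untested is made for them only; others in the source may bear on it.

Compound 1 `OCCCNc1nc(-c2ccccc2)nc2c1nnn2Cc1ccccc1Cl`: 33000000 nM in an assay on isolated protein for binding affinity to adenosine receptor A1 (Bos taurus); a higher number here means a weaker inhibitor, a lower number a stronger inhibitor
Compound 2 `OC1CCC(Nc2nc(-c3ccccc3)nc3c2nnn3Cc2ccccc2Cl)CC1`: 3100000 nM in this assay
Compound 3 `FC(F)(F)c1ccccc1Cn1nnc2c(NC3CCCC3)nc(-c3ccccc3)nc21`: 600000 nM in this assay

Among these three, compound 3 gives the lowest number in this assay, with compound 2 above it and compound 1 highest. Going by the values given here, the one step measured within the set, an 11-fold lower number from compound 1 to compound 2 (1.03 log units; beyond the scatter), concerns the group on the ring nitrogen and not the benzyl substituent. Compound 4 `Clc1ccccc1Cn1nnc2c(NC3CCCC3)nc(-c3ccccc3)nc21` differs from compound 3 by chloro in place of trifluoromethyl on an aromatic carbon. Among the compounds with values here, no measured step bears on this change, so the expectation rests on the shared core alone. Compound 4 is therefore estimated at 700000 nM, within 200000 nM to 2500000 nM, a step of a 1.2-fold higher number from compound 3 to compound 4 (0.07 log units; within the scatter) expected to stay within the usual scatter.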

Compound 4, inhibition constant: 9000000 nM
Estimate against measurement, compound 4: 13-fold (1.11 log units) below; the whole stated range lies below it.
By their numbers in this assay, from the lowest: compound 3; then compound 2; then compound 4; then compound 1.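

Going by these compounds alone, at this aromatic carbon, ortho to a large group, the substituent proves to matter in this assay: chloro in place of trifluoromethyl gives a 15-fold higher number from compound 3 to compound 4 (1.18 log units; beyond the scatter) and no earlier step touched this place. With chloro held fixed, cyclopentyl on the nitrogen gives a 2.9-fold higher number from compound 2 to compound 4 (0.46 log units; beyond the scatter) and also a 3.7-fold lower number from compound 1 to compound 4 (0.56 log units; beyond the scatter) so it ranks between 4-hydroxycyclohexyl and 3-hydroxypropyl. No evidence is available that accounts for these steps.

From the compounds shown here alone, whether bromo, methoxy or a nitrile at this carbon would read closer to chloro or trifluoromethyl stays open. So does whether 4-hydroxycyclohexyl and 3-hydroxypropyl keep their order with trifluoromethyl on the benzyl group.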